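The source may hold more compounds than are shown below. What is called first, only, known or untested is meant among the compounds shown, and "the series" means these compounds.

Compound 1 `O=C(Nc1cccc2nonc12)N1CCN(Cc2cccc(Oc3ccc(Cl)cc3)c2)CC1` gives 120 nM in an assay on isolated protein for inhibition of Fatty-acid amide hydrolase 1 (Rattus norvegicus), with a stated time of 60 min; a lower number here means a stronger inhibitor, a higher number a weaker inhibitor. Compound 2 `O=C(Nc1cncc2ccccc12)N1CCN(Cc2cccc(Oc3ccc(Cl)cc3)c2)CC1` gives 8.3 nM. Compound 3 `O=C(Nc1cn2ccccc2n1)N1CCN(Cc2cccc(Oc3ccc(Cl)cc3)c2)CC1` gives > 10000 nM, which is a limit of this assay and not a number.

Compound 3 therefore stands at the limit (the limit of > 10000 nM in this assay, at which 1 of the 3 values shown sits), the weakest point shown. Compound 4 `O=C(Nc1ccc2nccn2c1)N1CCN(Cc2cccc(Oc3ccc(Cl)cc3)c2)CC1` differs from it by a group of 9 heavy atoms (7 carbon, 2 nitrogen; one five-membered aromatic ring with 2 hetero atoms, one six-membered aromatic ring with 1 hetero atom) in place of a group of 9 heavy atoms (7 carbon, 2 nitrogen; one five-membered aromatic ring with 2 hetero atoms, one six-membered aromatic ring with 1 hetero atom), on an amide-type nitrogen. The measured steps that bear on this are an at least 83-fold higher number from compound 1 to compound 3 (1.92 log units; beyond the scatter) and an at least 1200-fold higher number from compound 2 to compound 3 (3.08 log units; beyond the scatter); both are large and both run into the limit, so they fix only where compound 3 sits, not how far beyond it. Rejoining the same atoms differently is expected to give a lower number, an at least 3.3-fold lower number from compound 3 to compound 4 (0.52 log units; beyond the scatter), though with wide uncertainty. Compound 4 is estimated at 3000 nM, in a range from 300 nM to 15000 nM.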

Compound 4, half-maximal inhibitory concentration: 3600 nM
For compound 4 the middle estimate is 1.2-fold (0.08 log units) below the measured one; measured number inside the range.
By their numbers in this assay, from the lowest: compound 2; then compound 1; then compound 4. At a limit, above all of these: compound 3.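

Rejoining the same atoms on the amide-type nitrogen gives a measurable number, an at least 2.7-fold lower number from compound 3 to compound 4 (0.44 log units; beyond the scatter), so in this pair the way the two rings are joined matters, not only which atoms they hold. Compound 3 stands at a limit and not at a number: the limit of > 10000 nM in this assay, at which 1 of the 4 values shown sits. The rejoined group still falls well short of the other two, with a 30-fold higher number from compound 1 to compound 4 (1.48 log units; beyond the scatter) and a 430-fold higher number from compound 2 to compound 4 (2.64 log units; beyond the scatter).

Going by these compounds, how far compound 3 lies beyond its limit remains open, and with it the full size of the rejoining step. Also open, on these data alone, is how a single pyridine or phenyl ring on this nitrogen would compare.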